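The source may hold more compounds than are shown below. What is called first, only, known or untested is meant among the compounds shown, and "the series" means these compounds.

Compound 1 `CCCCCCCCCCCCCCNC(=O)[C@@H](NC(=O)c1ccccc1)[C@@H](C)O` reaches only the limit > 200000 nM in a functional assay on SiHa cells (Homo sapiens) for cytotoxicity, read by MTT assay, with a stated time of 48 h; a lower number here means a stronger inhibitor, a higher number a weaker inhibitor.
Compound 2 `CCCCCCCCCCCCCCCCCCNC(=O)[C@@H](NC(=O)c1ccccc1)[C@@H](C)O` gives 38200 nM in this assay.

Compound 2 holds the only number among these two values; the other value is a limit, as the limit of > 200000 nM in this assay, at which 1 of the 2 values shown sits, shows. Within the data shown here, the single measured step, an at least 5.2-fold lower number from compound 1 to compound 2 (0.71 log units; beyond the scatter), concerns the chain alone and leaves the aromatic acyl part untouched.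

Compound 3 `CCCCCCCCCCCCCCCCCCNC(=O)[C@@H](NC(=O)c1cc2ccccc2[nH]1)[C@@H](C)O` keeps the chain and the core of compound 2 and differs by 1H-indol-2-yl in place of phenyl on a carbonyl carbon. Among the measured compounds shown here, no measured step touches this part of the molecule, so nothing in the data shows how this assay answers such a change; the chain step cannot be carried over. The step from compound 2 to compound 3 is therefore expected to stay within the scatter, in either direction. The expected step of a 1.1-fold lower number from compound 2 to compound 3 (0.04 log units; within the scatter) is taken as small. Compound 3 is estimated to give about 35000 nM, with a range from 9000 nM to 150000 nM.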

Compound 3, half-maximal inhibitory concentration: 29600 nM
For compound 3 the middle estimate is 1.2-fold (0.07 log units) above the measured one, and the stated range covers the measured number.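

Among these compounds, the step (a 1.3-fold lower number from compound 2 to compound 3 (0.11 log units; within the scatter)) is the first reading at this place, on a carbonyl carbon whose other neighbour is an amide-type nitrogen, and in this assay it shows that 1H-indol-2-yl and phenyl cannot be told apart there. Among the compounds shown here, the exchange brings in a five-membered aromatic ring and a hydrogen-bond donor, yet the step stays within the scatter, whereas the only earlier step (an at least 5.2-fold lower number from compound 1 to compound 2 (0.71 log units; beyond the scatter)) concerned the chain and lay beyond it. Nothing measured among these compounds points to a reason for this result.

As far as these compounds go, how a pyridine ring, or a phenyl carrying an amine or a carboxylic acid, would read at this place remains open. So does the effect of a chain longer than that of compound 2, and whether 1H-indol-2-yl would read the same on the shorter chain of compound 1.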